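The source may report more compounds than this note shows. Statements on the series, on what has been measured and on what is new or still open speak of the compounds shown alone.

Measured in a physicochemical assay for lipophilicity, at pH 7.4; on this read-out higher numbers stand for higher lipophilicity and lower numbers for lower lipophilicity:
- compound 1 `CCc1ccc(N(CC2CC2)S(=O)(=O)c2ccc3c(c2)C(=O)CC(C2CCOCC2)O3)cc1`: 3.77
- compound 2 `CCc1ccc(N(Cc2ccccc2)S(=O)(=O)c2ccc3c(c2)C(=O)CC(C2CCOCC2)O3)cc1`: 4.84
- compound 3 `Cc1ccc(NS(=O)(=O)c2ccc3c(c2)C(=O)CC(C2CCOCC2)O3)c(C)c1`: 2.75

Compound 3 has the lowest of the three numbers, at 2.75. Compound 1 comes nearest at 3.77, and compound 2 lies furthest at 4.84. Both gaps are beyond the scatter.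

Compound 4 `CCc1ccc(NS(=O)(=O)c2ccc3c(c2)C(=O)CC(C2CCOCC2)O3)cc1` has not yet been measured. It differs from compound 3 in one place: 4-ethylphenyl in place of 2,4-dimethylphenyl on a sulfonamide nitrogen. Here 4-ethylphenyl stands in place of 2,4-dimethylphenyl on a sulfonamide nitrogen, so the two have the same atoms, joined differently.

For the measured compounds named here, the only measured step, a number 1.07 log units higher from compound 1 to compound 2 (beyond the scatter), is large, but it puts phenyl in place of cyclopropyl on a saturated chain carbon, which is a different change. Compound 1 and compound 2 do carry 4-ethylphenyl, but their sulfonamide nitrogen bears a further group, unlike that of compound 4. Going by the values given here, with no measured step for this swap, the expected change is small, and none beyond the scatter is anticipated: a number 0.15 log units higher from compound 3 to compound 4 (within the scatter). For compound 4 the estimated value is 2.9, with an expected range from 2.5 to 3.4.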

Compound 4, distribution coefficient: 2.67
Estimate against measurement, compound 4: 0.23 log units above; low and high end bracket the measured number.
By their numbers in this assay, from the lowest: compounds 4 and 3 (each within the scatter of the next); then compound 1; then compound 2.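

In this assay, rearranging the same atoms from 2,4-dimethylphenyl to 4-ethylphenyl on a sulfonamide nitrogen gives a number 0.08 log units lower from compound 3 to compound 4 (within the scatter), so this swap makes no difference that can be told from the scatter. Compound 4 also shows directly what the further group on that nitrogen is worth: hydrogen in place of benzyl gives a number 2.17 log units lower from compound 2 to compound 4 (beyond the scatter), and hydrogen in place of cyclopropylmethyl gives a number 1.10 log units lower from compound 1 to compound 4 (beyond the scatter), both large steps. No measured evidence here gives a reason for the size of any of these steps.

Still open, from the compounds shown here alone, is how the number would respond to a longer chain carrying an amine or a carboxylic acid on the sulfonamide nitrogen. The compounds shown also leave open whether 2,4-dimethylphenyl and 4-ethylphenyl would stay this close if that nitrogen carried benzyl or cyclopropylmethyl.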